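A few compounds are considered here, and "the series" means these few. Any claim that something is new, unique, unknown or untested is made for them only; others in the source may bear on it.

Compound 3, with the structure `O=C(Nc1ccc(Cl)c(Cl)c1)N[C@@H]1C2CCN(CC2)[C@@H]1Cc1cccnc1`, gives in an assay on a protein complex for binding affinity to Neuronal acetylcholine receptor; alpha4/beta2 (Homo sapiens) (a lower number here means a stronger inhibitor, a higher number a weaker inhibitor), only a limit of the assay and no number: its value is > 10000 nM. Compound 1, the structure `O=C(Nc1cccc(Br)c1)N[C@@H]1C2CCN(CC2)[C@@H]1Cc1cccnc1`, gives in this assay a limit of > 10000 nM. Compound 2, the structure `CSc1ccc(NC(=O)N[C@@H]2C3CCN(CC3)[C@@H]2Cc2cccnc2)cc1`, likewise gives a limit of > 10000 nM. All three values sit at the limit of > 10000 nM in this assay, at which 3 of the 3 values shown sit, so the steps a step that the two limits leave unreadable from compound 1 to compound 2, a step that the two limits leave unreadable from compound 1 to compound 3 and a step that the two limits leave unreadable from compound 2 to compound 3 cannot be read in size or direction.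

Compound 4, the structure `Cn1cccc1C(=O)N[C@@H]1C2CCN(CC2)[C@@H]1Cc1cccnc1`, is the next compound to be measured. It differs from compound 3 by 1-methyl-1H-pyrrol-2-yl in place of (3,4-dichlorophenyl)amino on a carbonyl carbon. The measured steps all exchange one aromatic group for another on the amide-type nitrogen, while this change removes that nitrogen with its ring and puts a ring directly on the carbonyl carbon; none of them bears on it, and none gives a readable size anyway. With compound 3 at a limit of > 10000 nM, the expectation for compound 4 can only rest on that limit. Compound 4 is therefore expected near 15000 nM, within a range from 3000 nM to 60000 nM, and most likely again as a limit. That estimate would correspond to a step that the limit leaves unreadable from compound 3 to compound 4, a step that is not expected to be readable.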

Compound 4, inhibition constant: > 10000 nM
Compound 4 ended at the assay's limit; the forecaster's own chance of this, stated with the estimate: 70%; the middle value does not contradict the limit.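

Compound 4 gives only a limit, as do compound 1, compound 2 and compound 3, so the steps from each of them to compound 4 cannot be read in size or direction: the limit of > 10000 nM in this assay, at which 4 of the 4 values shown sit.

The compounds shown leave open which group on the carbonyl carbon, if any, would give a measurable value in this assay.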